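The source may report more compounds than this note shows. Statements on the series, on what has been measured and on what is new or still open speak of the compounds shown alone.

Compound 1 `N/C(=N\NC(=S)N1CCCC1)c1ccc(F)cn1` and compound 2 `N/C(=N\NC(=S)N1CCOCC1)c1ccc(F)cn1` share one core and differ only at a thiocarbonyl carbon. For the measured compounds named here, in a functional assay on HeLa cells (Homo sapiens) for cytotoxicity, read by MTT assay, with a stated time of 72 h, tested at 30 uM (on this read-out higher numbers stand for more inhibition of growth at the one concentration tested and lower numbers for less inhibition of growth), compound 1 gives 81.2%, and compound 2 gives 84.5%; the step of a number 3.3 percentage points higher from compound 1 to compound 2 (within the scatter) lies within the scatter, so compound 1 stands level with compound 2 on the numbers so far. Compound 3 `N/C(=N\NC(=S)N1CCCC1)c1ccccn1` differs from compound 1 by hydrogen in place of fluoro on an aromatic carbon. Going by the values given here, no measured step concerns this place, so only a step of a number 3.2 percentage points lower from compound 1 to compound 3 (within the scatter) that stays within the scatter is expected. Compound 3 is therefore estimated at 78%, within 60% to 92%.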

Compound 3, percent growth inhibition at one concentration: 84.5%
For compound 3 the middle estimate is 6.5 percentage points below the measured one; the measured number falls inside the stated range.
By their numbers in this assay, from the lowest: compounds 1, 2 and 3 (each within the scatter of the next).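

In this assay, hydrogen in place of fluoro on an aromatic carbon gives a number 3.3 percentage points higher from compound 1 to compound 3 (within the scatter), so the two compounds stand level and the fluoro is not required for the growth inhibition seen at this one concentration. This holds for the compounds carrying the pyrrolidin-1-yl group, the only setting in which this position can be read so far. No measured evidence bears on this result. Still open, on these data alone, is whether chlorine, a methoxy group or an amine at this place would give a similar number. As far as these compounds go, the same swap on compound 2, with its morpholin-4-yl group, also remains open.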